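This account rests on a few compounds, and the source may have more. Where it says the series, first, only, none or still open, it means among the compounds named here.

Measured in a functional assay on MCF7 cells (Homo sapiens) for inhibition, read by radiometric assay and XTT assay; on this read-out lower numbers stand for stronger inhibition and higher numbers for weaker inhibition:
- Compound 1 `CCCCCCCC[C@@]1(C)SC(O)=CC1=O`: 17.6 ug/mL
- Compound 2 `C=CCC1=C(O)S[C@](C)(CCCCCCCC)C1=O`: 44.4 ug/mL
- Compound 3 `CCCCCCCC[C@@]1(C)SC(O)=C(C(C)O)C1=O`: 23.9 ug/mL; 21 ug/mL (2 entries)

Compound 2 holds the highest of these numbers. Within the data shown here, the only measured step is a 2.5-fold higher number from compound 1 to compound 2 (0.40 log units; beyond the scatter), which puts allyl in place of hydrogen on a double-bonded ring carbon. Repeat readings agree closely, as the several entries of compound 3 in this assay, 23.9 ug/mL; 21 ug/mL (2 entries) shows.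

Compound 4 `CCCCCCCC[C@@]1(C)SC(O)=C(C(C)=O)C1=O` alters that same carbon of compound 2: acetyl in place of allyl on a double-bonded ring carbon. Compound 3 also carries an oxygen-bearing group there, and compound 3 reads 23.9 ug/mL; 21 ug/mL (2 entries), which points towards a lower number. In this assay, the step of a 1.6-fold lower number from compound 2 to compound 4 (0.20 log units; within the scatter) is therefore expected to be small, no larger than the measured one. For compound 4 the estimated value is 28 ug/mL, with an expected range from 11 ug/mL to 70 ug/mL.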

Compound 4, half-maximal inhibitory concentration: 12.5 ug/mL
Compound 4: middle estimate off by 2.2-fold (0.35 log units), on the high side; the range from low to high includes it.
By their numbers in this assay, from the lowest: compounds 4 and 1 (each within the scatter of the next); then compound 2.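

On this double-bonded ring carbon, acetyl in place of allyl gives a 3.6-fold lower number from compound 2 to compound 4 (0.55 log units; beyond the scatter) in this assay although both groups have the same count of heavy atoms, so that count alone does not set the read-out here. Acetyl in place of hydrogen gives a 1.4-fold lower number from compound 1 to compound 4 (0.15 log units; within the scatter) and so a group on this carbon need not shift the number the way allyl did. Repeat readings agree closely, which supports the larger step: the several entries of compound 3 in this assay, 23.9 ug/mL; 21 ug/mL (2 entries).

Which feature of acetyl matters stays open: the compounds shown carry no amine, carboxylic acid or longer acyl chain on this carbon.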